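Dibenzylamino analogue on a second imidazopyridine core: expected growth inhibition

A few compounds are considered here, and "the series" means these few. Any claim that something is new, unique, unknown or untested is made for them only; others in the source may bear on it.

Measured compounds:
compound 1, `Cc1ccc2nc(-c3ccc(N)cc3)cn2c1`, 65200 nM
compound 2, `Cc1ccc2nc(-c3ccc(NCc4ccccc4)cc3)cn2c1`, 42600 nM
compound 3, `Cc1ccn2cc(-c3ccc(NCc4ccccc4)cc3)nc2c1`, "not determined" (no result reported)

In a functional assay on LoVo cells (Homo sapiens) for antiproliferative activity, read by MTT assay, with a stated time of 72 h (a lower number here means a stronger inhibitor of growth, a higher number a weaker inhibitor of growth), compound 1 gives 65200 nM, and compound 2 gives 42600 nM. Between them lies (benzyl in place of hydrogen on a nitrogen on an aromatic ring), and the step is a 1.5-fold lower number from compound 1 to compound 2 (0.18 log units; within the scatter). Compound 3 shares the aminophenyl portion of compound 2 but carries a different core; the difference between the two cores is not broken down here, and in this assay compound 3 gives "not determined" (no result reported). Compound 4, `Cc1ccn2cc(-c3ccc(N(Cc4ccccc4)Cc4ccccc4)cc3)nc2c1`, differs from compound 3 by benzyl in place of hydrogen on a nitrogen on an aromatic ring. This is the same kind of change as from compound 1 to compound 2, though the place differs: in compound 1 the nitrogen's other neighbour is aromatic carbon only, whereas in compound 3 it has aromatic carbon and saturated chain carbon. Because the earlier benzyl step was a 1.5-fold lower number from compound 1 to compound 2 (0.18 log units; within the scatter), a similarly small effect is expected, but with compound 3 unmeasured the anchor is uncertain. Compound 4 is therefore estimated at 40000 nM, expected between 10000 nM and 120000 nM.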

Compound 4, concentration for 50% growth inhibition: 5700 nM
Compound 4: middle estimate off by 7.0-fold (0.85 log units), on the high side; the measured number lies below the stated range.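

Among the compounds shown here, no step from compound 3 to compound 4 can be read, as compound 3 has no single number for comparison. What the added benzyl contributes to the value of compound 4 stays open, and nothing shown explains that value.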